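Swapping the Aryl Group on a Shared Core

This account rests on a few compounds, and the source may have more. Where it says the series, first, only, none or still open, it means among the compounds named here.

Compound 2 `Brc1ccc(-c2cn3ccnc3c(-c3ccc4ncn(C5CCCCC5)c4c3)n2)cc1` gives 22.8% in a functional assay on MDA-MB-231 cells (Homo sapiens) for inhibition, read by sulforhodamine B assay, with a stated time of 48 h, tested at 10 uM (a higher number here means more inhibition at the concentration tested (going by the name of the read-out), a lower number less inhibition), and stands at the top of the two numbers measured, though compound 1 `c1ccc2c(-c3cn4ccnc4c(-c4ccc5ncn(C6CCCCC6)c5c4)n3)cccc2c1`, with 20.8%, lies within the scatter of it. For the measured compounds named here, the single step measured so far, a number 2 percentage points higher from compound 1 to compound 2 (within the scatter), exchanges the group at this same position and shifts the number only within the scatter. Compound 3 `c1csc(-c2cn3ccnc3c(-c3ccc4ncn(C5CCCCC5)c4c3)n2)c1` carries the change (thiophen-2-yl in place of 4-bromophenyl on an aromatic carbon). Because the earlier exchange at this position gave a number 2 percentage points higher from compound 1 to compound 2 (within the scatter), the step of a number 0.8 percentage points lower from compound 2 to compound 3 (within the scatter) is expected to remain within the scatter. Compound 3 is therefore estimated at 22%, spanning 10% to 35%.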

Compound 3, a percentage reported as inhibition, at one concentration (the size of the read-out at that concentration, not a potency): 10.8%
Estimate against measurement, compound 3: 11.2 percentage points above; low and high end bracket the measured number.
By their numbers in this assay, from the lowest: compounds 3, 1 and 2 (each within the scatter of the next, the first and the last beyond it).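

For the compounds shown here, the position is less indifferent than the first exchange suggested: in this assay thiophen-2-yl gives a number 12 percentage points lower from compound 2 to compound 3 (beyond the scatter) and this is the first step to pass the scatter. The same group gives a number 10 percentage points lower from compound 1 to compound 3 (within the scatter) and that step stays within the scatter, so the change shows clearly only against 4-bromophenyl. No measurement here accounts for this difference. Still open, from the compounds shown here alone, is how the position responds to a non-aromatic group such as an amine or a carboxylic acid, and whether any group there gives much more inhibition than these three.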